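The source may report more compounds than this note shows. Statements on the series, on what has been measured and on what is new or still open speak of the compounds shown alone.

Measured compounds:
Compound 1, `O=C1C=C[C@]2(O)CCO[C@@H]2C1`: 2.1 ug/mL
Compound 2, `CC(=O)O[C@]12C=CC(=O)C[C@H]1OCC2`: 0.5 ug/mL

Compound 1 and compound 2 share a core and differ only at one oxygen on a saturated carbon. In a functional assay on P388 cells (Mus musculus) for cytotoxicity (a lower number here means a stronger inhibitor, a higher number a weaker inhibitor), compound 1 gives 2.1 ug/mL, and compound 2 gives 0.5 ug/mL. For the measured compounds named here, the single known step, a 4.2-fold lower number from compound 1 to compound 2 (0.62 log units; beyond the scatter), places compound 2 at the lowest of the two numbers, with compound 1 as its only neighbour.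

Compound 3, `CCCC(=O)O[C@]12C=CC(=O)C[C@H]1OCC2`, extends the acyl group of compound 2: ethyl in place of hydrogen on a saturated chain carbon bound to a carbonyl carbon. Cut one bond further out, the change reads acetyl to propylcarbonyl.

Going by the values given here, no measured step speaks to lengthening the chain on the acyl group itself; the one step known, from hydrogen to acetyl, concerns putting the acyl group in place rather than growing it. That step was modest and beyond the scatter, but it offers no direction for the present change. Compound 3 is therefore expected to stay close to compound 2 in this assay, with a step of no change at the digits printed from compound 2 to compound 3 (within the scatter) that is estimated to lie within the scatter. The estimate for compound 3 is 0.5 ug/mL, expected between 0.2 ug/mL and 1.2 ug/mL.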

Compound 3, half-maximal inhibitory concentration: 0.6 ug/mL
For compound 3 the middle estimate is 1.2-fold (0.08 log units) below the measured one; measured number inside the range.
By their numbers in this assay, from the lowest: compounds 2 and 3 (each within the scatter of the next); then compound 1.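

In this assay the acyl group on the oxygen can be lengthened from acetyl to propylcarbonyl with no reading of a difference: ethyl in place of hydrogen on a saturated chain carbon bound to a carbonyl carbon gives a 1.2-fold higher number from compound 2 to compound 3 (0.08 log units; within the scatter) and so leaves compound 3 level with compound 2. The lower number that came with acylating the oxygen on a saturated carbon, a 4.2-fold lower number from compound 1 to compound 2 (0.62 log units; beyond the scatter) for acetyl, now appears with a second acyl group as well, a 3.5-fold lower number from compound 1 to compound 3 (0.54 log units; beyond the scatter), so among these compounds it does not depend on acetyl alone and both acylated compounds stand beyond the scatter from compound 1. Nothing in the available evidence bears on why the two acyl groups read alike or why either differs from the free hydroxyl.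

The compounds shown leave open how far this tolerance of the acyl chain extends, for instance whether a longer chain such as octanoyl or a ring-bearing acyl group such as benzoyl would stay level with compound 2 in this assay. They also leave open whether the lower number needs the ester at all, as a methyl ether or a carbamate on the same oxygen would show.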